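This account rests on a few compounds, and the source may have more. Where it says the series, first, only, none or still open, it means among the compounds named here.

The series shares a single core, shown with compound 1 `COc1cccc(/C=C/C(=O)c2cc3ccc(O)cc3oc2=O)c1OC`, and differs only in the aryl group at the far end of the enone. In a functional assay on K562 cells (Homo sapiens) for cytotoxicity, read by MTT assay, with a stated time of 72 h (a higher number here means a weaker inhibitor, a lower number a stronger inhibitor), compound 1 gives 14600 nM. Compound 2 `COC(=O)c1ccc(/C=C/C(=O)c2cc3ccc(O)cc3oc2=O)cc1` gives 4400 nM in this assay, and compound 3 `COc1cc(/C=C/C(=O)c2cc3ccc(O)cc3oc2=O)cc(OC)c1OC` gives 7300 nM. Among the compounds with values here, of these three numbers the one for compound 1 is the highest; its gap to compound 3 lies within the scatter of repeated measurements, so nothing can be said about their order, while its gap to compound 2 lies beyond the scatter, so compound 2 is the stronger of that pair.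

Compound 4 `COc1cccc(COc2ccc3cc(C(=O)/C=C/c4cccc(OC)c4OC)c(=O)oc3c2)c1` keeps the aryl group of compound 1 and changes the core: 3-methoxybenzyl in place of hydrogen on an oxygen on an aromatic ring. Within the data shown here, no measured pair in this set shows what such a change does in this assay, so the expectation rests on the structural change alone. Compound 4 is expected to move only modestly, toward a somewhat lower number than compound 1, a step of a 1.3-fold lower number from compound 1 to compound 4 (0.12 log units; within the scatter) that is not expected to be clearly beyond the scatter. Compound 4 is accordingly estimated at 11000 nM in this assay, within a range from 3500 nM to 35000 nM.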

Compound 4, half-maximal inhibitory concentration: 45500 nM
Compound 4: middle estimate off by 4.1-fold (0.62 log units), on the low side; the whole stated range lies below it.
By their numbers in this assay, from the lowest: compounds 2, 3 and 1 (each within the scatter of the next, the first and the last beyond it); then compound 4.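

Within the data shown here, the hydroxy on the shared core stayed constant across compounds 1, 2 and 3, so only the aryl group at the far end of the enone could be read from them; compound 4 gives the first reading at this oxygen. In this assay, the change from hydroxy to (3-methoxybenzyl)oxy gives a 3.1-fold higher number from compound 1 to compound 4 (0.49 log units; beyond the scatter), so this position is not silent to substitution, and this large ether moves the compound toward weaker inhibition rather than leaving it unchanged. Nothing given here accounts for this step, which remains a single observation on the aryl group of compound 1.

The compounds shown leave open whether the step follows from replacing the hydrogen of the hydroxy at all or from the size and nature of the 3-methoxybenzyl group, a question that a simple methyl ether, or a short chain ending in an amine or a carboxylic acid, would bear on. They also leave open whether the same change would carry the same direction and size with the aryl groups of compound 2 and compound 3.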